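Amino for fluoro on the compound 3 core, before measurement

The source may hold more compounds than are shown below. What is called first, only, known or untested is meant among the compounds shown, and "the series" means these compounds.

Three compounds have numbers in an ADME assay on L02 cells (Homo sapiens) for inhibition, read by MTT assay, with a stated time of 48 h, tested at 100 uM; a lower number here means less inhibition, a higher number more inhibition at the concentration tested (going by the name of the read-out). Compound 1 `Cc1ccc(-c2nc(=O)ss2)s1` gives 36.3%, compound 2 `Nc1ccc(-c2nsc(=O)o2)cc1` gives 39.5%, and compound 3 `O=c1nc(-c2ccc(F)cc2)ss1` gives 33.7%. Compound 3 has the lowest of the three numbers, but its gaps to compound 1 and to compound 2 both lie within the scatter, so no order among them can be read. Compound 4 `Nc1ccc(-c2nc(=O)ss2)cc1` has not yet been measured; it differs from compound 3 by amino in place of fluoro on an aromatic carbon. Compound 2 also carries amino, on a different core, and its number sits within the scatter of compound 3. Among the measured compounds shown here, no step between measured compounds is available for this change, so no direction beyond the scatter is expected. Compound 4 is estimated at 38%, between 28% and 48%, an expected step of a number 4.3 percentage points higher from compound 3 to compound 4 (within the scatter).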

Compound 4, a percentage reported as inhibition, at one concentration (the size of the read-out at that concentration, not a potency): 46.3%
Compound 4: middle estimate off by 8.3 percentage points, on the low side, and the stated range covers the measured number.
By their numbers in this assay, from the lowest: compounds 3, 1, 2 and 4 (each within the scatter of the next, the first and the last beyond it).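

In this assay, amino in place of fluoro on an aromatic carbon of the shared core gives a number 12.6 percentage points higher from compound 3 to compound 4 (beyond the scatter). Among the compounds shown here, this is the first single-place change, and it shows that the number responds to the group at this position, which the earlier compounds, differing in more than one place, could not show. Nothing available gives a reason for this step.

Open, going by these compounds, is whether a dimethylamino group, a hydroxyl or a carboxylic acid at this position would move the number the same way. Also open, on these data alone, is whether amino in place of fluoro gives a similar step on the core of compound 2.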